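A ring swap on compound 2

The compounds below may be only part of what the source reports. "The series", "measured", "known", "first", "only" and "open" are said of these compounds alone.

In an ADME assay on microsomes from liver (Mus musculus) for metabolic stability, read by LC-MS, using NADPH, with stated times of 15 min and 60 min, tested at 4.6 uM (on this read-out lower numbers stand for a shorter-lived compound and higher numbers for a longer-lived compound), compound 1 (`CC(=O)N1CCC(c2ccc3c(c2)oc(=O)n3C(=O)NCCCCc2ccccc2)CC1`) gives 1 h, compound 2 (`CN1CCC(c2ccc3c(c2)oc(=O)n3C(=O)NCCCCc2ccccc2)CC1=O`) gives 0.583 h and compound 3 (`CC(C)CNC(=O)n1c(=O)oc2c(C3CCN(C)CC3)cccc21`) gives 0.5 h. Compound 2 thus lies within the usual scatter of both others. Compound 4 (`CN1CCN(c2ccc3c(c2)oc(=O)n3C(=O)NCCCCc2ccccc2)CC1`) carries 4-methylpiperazin-1-yl in place of 1-methyl-2-oxopiperidin-4-yl on an aromatic carbon. Going by the values given here, only one measured step exchanges a group at an aromatic carbon with all else kept: a 1.7-fold lower number from compound 1 to compound 2 (0.23 log units; within the scatter). Among the compounds with values here, compound 3 differs from compound 2 in more than one place, so it gives no such step. The step expected is a 1.2-fold lower number from compound 2 to compound 4 (0.07 log units; within the scatter), which is nothing beyond the scatter. Compound 4 is estimated at 0.5 h, with an expected range of 0.2 h to 1 h.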

Compound 4, half-life: < 0.0834 h
Compound 4: no number, only a limit; the forecaster's own chance of this, stated with the estimate: 3%; at least 5.9-fold (0.77 log units) between middle value and limit.
By their numbers in this assay, from the lowest: compounds 3, 2 and 1 (each within the scatter of the next). At a limit, below all of these: compound 4.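

In this assay, the group on this aromatic carbon can matter: swapping one group there gave only a 1.7-fold lower number from compound 1 to compound 2 (0.23 log units; within the scatter), whereas 4-methylpiperazin-1-yl gives an at least 6.9-fold lower number from compound 2 to compound 4 (0.84 log units; beyond the scatter) and an at least 11-fold lower number from compound 1 to compound 4 (1.07 log units; beyond the scatter). Compound 4 has a limit rather than a number, so the full size of both steps stays unknown: the limit of < 0.0834 h in this assay, at which 1 of the 4 values shown sits.

The compounds shown leave open whether this drop belongs to the piperazine ring itself or to its methyl group. A 4-acetylpiperazin-1-yl or a morpholin-4-yl group at this place would help separate the two.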